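A few compounds are considered here, and "the series" means these few. Any claim that something is new, unique, unknown or untested is made for them only; others in the source may bear on it.

Of the compounds shown here, three sharing one core have been measured in a functional assay on HT-29 cells (Homo sapiens) for inhibition, read by luminescence and CellTiter-Glo, with a stated time of 24 h; on this read-out lower numbers stand for an effect already at smaller amounts and higher numbers for an effect only at larger amounts of compound. Compound 1 `COCCn1nc(C(=O)N[C@H]2COc3ccccc3N(C)C2=S)nc1Cc1ccccc1` gives 566 nM, compound 2 `CN1C(=S)[C@@H](NC(=O)c2nc(Cc3ccccc3)n(CCC(F)(F)F)n2)COc2ccccc21` gives 1550 nM, and compound 3 `CN1C(=S)[C@@H](NC(=O)c2nc(Cc3ccccc3)n(CCCC#N)n2)COc2ccccc21` gives 2400 nM. Compound 3 cannot be told apart from its nearest neighbour, as a 1.5-fold higher number from compound 2 to compound 3 (0.19 log units; within the scatter) shows, but it stands clearly apart from the methoxy-bearing chain, as a 4.2-fold higher number from compound 1 to compound 3 (0.63 log units; beyond the scatter) shows.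

Compound 4 `CN1C(=S)[C@@H](NC(=O)c2nc(Cc3ccccc3)n(C3CCCC3)n2)COc2ccccc21` carries cyclopentyl in place of 3-cyanopropyl on an aromatic nitrogen. The measured steps bear on this only indirectly, as each alters a chain on an aromatic nitrogen and none puts a ring there. Besides the two steps above, the data offer a 2.7-fold higher number from compound 1 to compound 2 (0.44 log units; beyond the scatter), so the steps run from within the scatter to modest. No step beyond a modest one is therefore expected in this assay, and the direction is uncertain, with a slight lean towards a lower number. The expected step is a 1.8-fold lower number from compound 3 to compound 4 (0.27 log units; within the scatter). Compound 4 is estimated at 1300 nM, with an expected range from 400 nM to 4200 nM.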

Compound 4, half-maximal effective concentration: 3530 nM
For compound 4 the middle estimate is 2.7-fold (0.43 log units) below the measured one; the measured number falls inside the stated range.
By their numbers in this assay, from the lowest: compound 1; then compounds 2, 3 and 4 (each within the scatter of the next, the first and the last beyond it).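

In this assay the first ring placed on this aromatic nitrogen can't be told apart from the open chain it replaces, as a 1.5-fold higher number from compound 3 to compound 4 (0.17 log units; within the scatter) shows, even though cyclopentyl has neither the nitrile nor the hydrogen-bond acceptor of 3-cyanopropyl. The ring does stand apart from the other two chains, with a 2.3-fold higher number from compound 2 to compound 4 (0.36 log units; beyond the scatter) and a 6.2-fold higher number from compound 1 to compound 4 (0.79 log units; beyond the scatter) both beyond the scatter. Among these four compounds, therefore, compound 1 with its 2-methoxyethyl chain keeps the lowest number, and neither the ring nor the other chains come close to it.

As far as these compounds go, it remains open whether an amine or a carboxylic acid at the end of the chain, a longer ether chain, or cyclopropyl in place of cyclopentyl would read differently here. Nothing available explains why these groups differ as they do.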